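Sulfonohydrazide series: acetamidophenyl to dichlorophenyl on the sulfonyl

The compounds below may be only part of what the source reports. "The series", "measured", "known", "first", "only" and "open" are said of these compounds alone.

Measured so far:
compound 1, `CC(=O)Nc1ccc(S(=O)(=O)NNC(=O)c2cccnc2Nc2ccc(Cl)cc2)cc1` — > 100000 nM
compound 2, `O=C(NNS(=O)(=O)c1ccc(F)cc1)c1cccnc1Nc1ccc(Cl)cc1Cl` — 40700 nM

Both values come from a functional assay on A549 cells (Homo sapiens) for antiproliferative activity; a higher number here means a weaker inhibitor of growth, a lower number a stronger inhibitor of growth. For compound 1 the reported figure is a limit of the assay and not a number: the limit of > 100000 nM in this assay, at which 1 of the 2 values shown sits. Compound 2 gives 40700 nM in this assay. Compound 1 and compound 2 differ in more than one place, so their two values stand side by side without a counted step between them. Among the two values shown, compound 1 is the one marked only by a limit.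

Compound 3, `O=C(NNS(=O)(=O)c1ccc(Cl)cc1Cl)c1cccnc1Nc1ccc(Cl)cc1`, has not yet been measured in this assay. It differs from compound 1 in one place: 2,4-dichlorophenyl in place of 4-acetamidophenyl on a sulfonyl sulfur. Going by the values given here, no step between measured compounds covers this change, so its size is not known from the data. In this assay a step of moderate size from compound 1 toward stronger growth inhibition in compound 3 is expected, with a fair chance that the result again stops at the limit. The expected step is an at least 2.0-fold lower number from compound 1 to compound 3 (0.30 log units; that floor lies within the scatter). The estimate for compound 3 is 50000 nM, with a range from 15000 nM to 150000 nM.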

Compound 3, concentration for total growth inhibition: 70800 nM
Estimate against measurement, compound 3: 1.4-fold (0.15 log units) below; the range from low to high includes it.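

In this assay, going by these compounds alone, 2,4-dichlorophenyl in place of 4-acetamidophenyl on a sulfonyl sulfur gives the first step that changes one place only, namely an at least 1.4-fold lower number from compound 1 to compound 3 (0.14 log units; that floor lies within the scatter), and that floor lies within the scatter. The figure for compound 1 is a limit of the assay and not a number, so this step has a lower bound but no measured size: the limit of > 100000 nM in this assay, at which 1 of the 3 values shown sits. As far as these compounds go, what the change adds is that compound 3, with 2,4-dichlorophenyl on the sulfonyl sulfur and the rest of the core of compound 1, reads as a number in this assay, giving a measured reference for further changes at this position, while the true size of the step from the acetamidophenyl compound stays unknown.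

Compound 2 and compound 3 differ in more than one place, so the compounds shown do not separate the contribution of each aryl group, and one pair cannot establish a trend at the sulfonyl sulfur. From the compounds shown here alone, it remains open how this assay responds when this position carries a ring bearing a carboxylic acid or an amine, or a longer chain in place of the aromatic ring.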